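Swapping one bromo for chloro in a bis-halogenated pyrazole aniline

The source may hold more compounds than are shown below. What is called first, only, known or untested is meant among the compounds shown, and "the series" means these compounds.

Measured compounds:
compound 1, `Clc1ccc(NCc2cn(-c3ccccc3)nc2-c2ccc(Cl)cc2)cc1`, 2280 nM
compound 2, `Cc1ccc(NCc2cn(-c3ccccc3)nc2-c2ccc(Cl)cc2)cc1`, 3110 nM
compound 3, `Brc1ccc(NCc2cn(-c3ccccc3)nc2-c2ccc(Br)cc2)cc1`, 5000 nM

In a functional assay on MCF7 cells (Homo sapiens) for antiproliferative activity, read by MTT assay, with a stated time of 48 h (a lower number here means a stronger inhibitor, a higher number a weaker inhibitor), compound 3 gives the highest of the three numbers. Compound 2 gives 3110 nM, which lies within the scatter of compound 3; compound 1 gives 2280 nM, and the gap from compound 3 to compound 1 lies beyond the scatter. Compound 4, `Clc1ccc(-c2nn(-c3ccccc3)cc2CNc2ccc(Br)cc2)cc1`, is not yet measured. It differs from compound 3 in one place: chloro in place of bromo on an aromatic carbon.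

For the measured compounds named here, no measured step is the same exchange. Going by the values given here, the only step on record, a 1.4-fold higher number from compound 1 to compound 2 (0.13 log units; within the scatter), is a different change on the same ring and within the scatter. What the two values of compound 1 and compound 3 show is that the all-chloro compound sits lower than the all-bromo compound, and compound 4 stands halfway between them in structure. A modest move toward the lower number is therefore expected, roughly a 1.5-fold lower number from compound 3 to compound 4 (0.17 log units; within the scatter), though it may well stay inside the scatter. Compound 4 is estimated at 3400 nM, between 1700 nM and 6800 nM.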

Compound 4, half-maximal inhibitory concentration: 2620 nM
For compound 4 the middle estimate is 1.3-fold (0.11 log units) above the measured one; measured number inside the range.
By their numbers in this assay, from the lowest: compounds 1, 4, 2 and 3 (each within the scatter of the next, the first and the last beyond it).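

In this assay, for the compounds shown here, the first one-place exchange of bromo for chloro on this ring gives a 1.9-fold lower number from compound 3 to compound 4 (0.28 log units; within the scatter), so replacing the 4-bromophenyl with 4-chlorophenyl does not move the number beyond the scatter. With that 4-chlorophenyl held constant, the substituent on the other aromatic ring can be chloro, methyl or bromo without a step beyond the scatter: the steps are a 1.1-fold higher number from compound 1 to compound 4 (0.06 log units; within the scatter) and a 1.2-fold lower number from compound 2 to compound 4 (0.07 log units; within the scatter). No evidence is available to explain these numbers.

The compounds shown leave open whether a group of another kind at either site, such as an amine, a carboxylic acid or a methoxy group, would produce a step beyond the scatter. They also leave open how the unsubstituted phenyl would compare with these halogenated rings.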